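This account rests on a few compounds, and the source may have more. Where it says the series, first, only, none or still open, it means among the compounds named here.

Measured compounds in a functional assay on HT-29 cells (Homo sapiens) for cytotoxicity, read by MTT assay, with a stated time of 24 h, tested at 32 ug/mL; a lower number here means a weaker effect, a higher number a stronger effect of the compound at the concentration tested:
- compound 1 `Cn1c(-c2ccc(NC(=O)CSc3nc4ccccc4o3)cc2)nc(-c2ccccc2)c1-c1ccccc1`: 79.3%
- compound 2 `Cc1ccc2oc(SCC(=O)Nc3ccc(-c4nc(-c5ccccc5)c(-c5ccccc5)n4C)cc3)nc2c1`: 59.5%
- compound 3 `Cn1c(-c2ccc(NC(=O)CSC3=NCCS3)cc2)nc(-c2ccccc2)c1-c1ccccc1`: 59.4%

Compound 1 stands highest of the three numbers; its nearest neighbour is compound 2, a step of a number 19.8 percentage points lower from compound 1 to compound 2 (beyond the scatter), and its furthest is compound 3, a step of a number 19.9 percentage points lower from compound 1 to compound 3 (beyond the scatter). Compound 2 and compound 3 sit within the scatter of each other, as a number 0.1 percentage points lower from compound 2 to compound 3 (within the scatter) shows.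

Compound 4 `CN(C)/C=C/N1CCN(CC(=O)Nc2ccc(-c3nc(-c4ccccc4)c(-c4ccccc4)n3C)cc2)CC1` is not yet measured. It differs from compound 1 in one place: 4-(2-(dimethylamino)ethenyl)piperazin-1-yl in place of (1,3-benzoxazol-2-yl)sulfanyl on a saturated chain carbon bound to a carbonyl carbon.

Both measured steps from compound 1 bear on this change, since both alter the group carried on the sulfur side of the amide. Adding a methyl on an aromatic carbon of the departing group gave a number 19.8 percentage points lower from compound 1 to compound 2 (beyond the scatter), and replacing the aromatic ring pair with a smaller five-membered non-aromatic ring gave a number 19.9 percentage points lower from compound 1 to compound 3 (beyond the scatter). Each step was modest and downward. Among the measured compounds shown here, the change to compound 4 is larger than either, removing the sulfur and both aromatic rings and bringing in a six-membered non-aromatic ring with a double bond outside rings, so a downward step in this assay of at least modest size is expected, with wide uncertainty because no measured pair covers such a replacement.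

The estimated step is a number 27.3 percentage points lower from compound 1 to compound 4 (beyond the scatter). For compound 4 the expected value in this assay is 52%, estimated within 28% to 75%.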

Compound 4, a percentage reported as activity, at one concentration (the size of the read-out at that concentration, not a potency): 29.8%
Estimate against measurement, compound 4: 22.2 percentage points above, within the range that was stated.
By their numbers in this assay, from the lowest: compound 4; then compounds 3 and 2 (each within the scatter of the next); then compound 1.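

In this assay, the group on the saturated chain carbon bound to a carbonyl carbon can move the read-out much further than the earlier modest steps indicated: a number 49.5 percentage points lower from compound 1 to compound 4 (beyond the scatter) is a large step, the first in the series. The two compounds that sit within the scatter of each other, despite carrying different groups on the sulfur, both stand clearly above the piperazine compound, with a number 29.7 percentage points lower from compound 2 to compound 4 (beyond the scatter) and a number 29.6 percentage points lower from compound 3 to compound 4 (beyond the scatter), so among these four compounds every group attached through sulfur, whether its ring system is aromatic or not, gives a higher number than the sulfur-free 4-(2-(dimethylamino)ethenyl)piperazin-1-yl group, with no compound going against this. No measurement shown here explains the drop.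

As far as these compounds go, the change to compound 4 replaces the sulfur, the ring system and the terminal substituent in one step, so the part responsible for the lower number remains open; a plain piperazin-1-yl group, a 4-methylpiperazin-1-yl group or a morpholine ring on the same carbon would help separate these parts. From the compounds shown here alone, all four numbers come from a single concentration, so potency across the series also remains open.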